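Swapping the halobenzyl on the triazole arm

The source may hold more compounds than are shown below. What is called first, only, known or untested is meant among the compounds shown, and "the series" means these compounds.

Compound 1 `COc1ccc(/C=C2\CN(C(=S)SCc3cn(Cc4ccc(F)cc4)nn3)C/C(=C\c3ccc(OC)cc3)C2=O)cc1` and compound 2 `Cc1ccc(/C=C2\CN(C(=S)SCc3cn(Cc4ccc(F)cc4)nn3)C/C(=C\c3ccc(C)cc3)C2=O)cc1` both carry a 4-fluorobenzyl group on the triazole; the difference between their two cores is not broken down here. In a functional assay on PC-3 cells (Homo sapiens) for cytotoxicity, read by MTT assay, with a stated time of 24 h (on this read-out higher numbers stand for weaker inhibition and lower numbers for stronger inhibition), compound 1 gives 45600 nM. In this assay compound 2 gives 45500 nM, and the two values sit within the scatter of each other. Compound 3 `Cc1ccc(/C=C2\CN(C(=S)SCc3cn(Cc4cccc(Cl)c4)nn3)C/C(=C\c3ccc(C)cc3)C2=O)cc1` differs from compound 2 by 3-chlorophenyl in place of 4-fluorophenyl on a saturated chain carbon bound to an aromatic nitrogen. In this assay compound 3 reaches only a limit of the assay, > 80000 nM. The measured step is an at least 1.7-fold higher number from compound 2 to compound 3 (0.24 log units; that floor lies within the scatter). That value of compound 3 sits at the limit of > 80000 nM in this assay, at which 1 of the 3 values shown sits. Compound 4 `COc1ccc(/C=C2\CN(C(=S)SCc3cn(Cc4cccc(Cl)c4)nn3)C/C(=C\c3ccc(OC)cc3)C2=O)cc1` is related to compound 1 by the same change, (3-chlorophenyl in place of 4-fluorophenyl on a saturated chain carbon bound to an aromatic nitrogen), at the same place. The expectation for it rests on compound 1, which gives 45600 nM. It also rests on the measured step of an at least 1.7-fold higher number from compound 2 to compound 3 (0.24 log units; that floor lies within the scatter). For compound 4 the expected step is a 1.9-fold higher number from compound 1 to compound 4 (0.27 log units; within the scatter). Compound 4 is estimated at 85000 nM in this assay, with a range from 40000 nM to 200000 nM, and a limit rather than a number is a real possibility.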

Compound 4, half-maximal inhibitory concentration: > 80000 nM
Compound 4: only a limit was reported; the forecaster's own chance of this, stated with the estimate: 55%; the middle value does not contradict the limit.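

In this assay compound 4 reaches only a limit of the assay, > 80000 nM. On the core of compound 1, 4-fluorobenzyl to 3-chlorobenzyl gives an at least 1.7-fold higher number from compound 1 to compound 4 (0.24 log units; that floor lies within the scatter), so the change points the same way on both cores shown, though neither floor lies beyond the scatter, and the comparison with the earlier step reads: the same change on two cores in this assay, an at least 1.7-fold higher number (0.24 log units; that floor lies within the scatter) from compound 2 to compound 3 and an at least 1.7-fold higher number (0.24 log units; that floor lies within the scatter) from compound 1 to compound 4; the limit leaves it open whether they differ. What this does not show is how large the change is on either core, or whether it is the same size on both, since the two 3-chlorobenzyl compounds stop at one ceiling: the limit of > 80000 nM in this assay, at which 2 of the 4 values shown sit.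

The compounds shown leave open whether the fluorine, the chlorine or the place of the halogen matters here, which a 4-chlorobenzyl or a 3-fluorobenzyl group on the triazole would help to separate. They also leave open how an unsubstituted benzyl group, or a benzyl group carrying an amine or a carboxylic acid, would read on either core.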